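The compounds below may be only part of what the source reports. "The series", "measured", "known", "first", "only" and "open" are said of these compounds alone.

Compound 1 `Cc1ccc2c(O)cc(-c3cccc(Cl)c3)nc2n1`: > 100000 nM (a limit)
Compound 2 `Cc1cc(C)c2c(O)cc(-c3cccc(F)c3)nc2n1`: 12.9 nM

Among the measured compounds shown here, in a functional assay on MDA-N cells (Homo sapiens) for antiproliferative activity (on this read-out higher numbers stand for weaker inhibition of growth and lower numbers for stronger inhibition of growth), compound 2 gives 12.9 nM, the only true number available so far on this read-out. Compound 1 gives > 100000 nM, which is a limit of the assay and not a number.

The next compound, compound 3 `Cc1cc(C)c2c(O)cc(-c3cccc(Cl)c3)nc2n1`, has chloro in place of fluoro on an aromatic carbon, meta to a large group (chloro in place of fluoro on an aromatic carbon). For the measured compounds named here, no measured pair shows this exchange on its own, so there is no direct guide to the size of the step. In this assay, the expected change a 2.3-fold higher number from compound 2 to compound 3 (0.37 log units; beyond the scatter) is modest, toward weaker inhibition of growth and close to the edge of the usual scatter. Going by the values given here, the expected range is wider on the weak side, as only one number anchors it. For compound 3 the estimate is 30 nM, with an expected range from 8 nM to 250 nM.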

Compound 3, concentration for 50% growth inhibition: 19.1 nM
The estimate for compound 3 lay 1.6-fold (0.20 log units) above the measured number, within the range that was stated.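

In this assay, chloro in place of fluoro on an aromatic carbon, meta to a large group, gives a 1.5-fold higher number from compound 2 to compound 3 (0.17 log units; within the scatter), so on this read-out the two halogens cannot be told apart at this position. The methyl in place of hydrogen on an aromatic carbon carries far more weight, with an at least 5200-fold lower number from compound 1 to compound 3 (3.71 log units; beyond the scatter). Compound 1 stands at a limit of the assay and not at a number, so that step gives only a bound and not a true size: the limit of > 100000 nM in this assay, at which 1 of the 3 values shown sits.

On these data alone, it remains open whether a methoxy, a trifluoromethyl or an amine in place of the halogen would keep the number where chloro and fluoro leave it. As far as these compounds go, it is also open how an ethyl in place of the decisive methyl would read in this assay.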